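A few compounds are considered here, and "the series" means these few. Any claim that something is new, unique, unknown or untested is made for them only; others in the source may bear on it.

Measured in a functional assay on OVCAR-8 cells (Homo sapiens) for inhibition, read by colorimetric assay and sulforhodamine B assay, with a stated time of 48 h; a lower number here means a stronger inhibitor of growth, a higher number a weaker inhibitor of growth:
Compound 1 `CCCCCCCCCCCC[C@@H](O)[C@H]1CC[C@H]([C@H](O)CCCCCCCCCCNC(=O)c2cccs2)O1`: 3020 nM
Compound 2 `CCCCCCCCCCCC[C@@H](O)[C@H]1CC[C@H]([C@H](O)CCCCCCCCCCNC(=O)c2ccoc2)O1`: 66100 nM
Compound 3 `CCCCCCCCCCCC[C@@H](O)[C@H]1CC[C@H]([C@H](O)CCCCCCCCCCNC(=O)c2cncs2)O1`: 100000 nM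

Compound 3 cannot be told apart from compound 2, with a 1.5-fold higher number from compound 2 to compound 3 (0.18 log units; within the scatter), whereas compound 1 gives a far lower number, with a 33-fold higher number from compound 1 to compound 3 (1.52 log units; beyond the scatter). Compound 4 `CCCCCCCCCCCC[C@@H](O)[C@H]1CC[C@H]([C@H](O)CCCCCCCCCCNC(=O)c2ccsc2)O1` carries one change from compound 3: thiophen-3-yl in place of 1,3-thiazol-5-yl on a carbonyl carbon, (thiophen-3-yl in place of 1,3-thiazol-5-yl on a carbonyl carbon). The nearest measured group by name is the thiophen-2-yl of compound 1, yet a 22-fold higher number from compound 1 to compound 2 (1.34 log units; beyond the scatter) shows how much one such swap can move the number, so only a partial move toward compound 1 is expected. A clear step to a lower number is therefore expected in this assay, estimated as an 8.3-fold lower number from compound 3 to compound 4 (0.92 log units; beyond the scatter). For compound 4 the estimated value is 12000 nM, with an expected range of 2500 nM to 60000 nM.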

Compound 4, concentration for 50% growth inhibition: 1910 nM
Compound 4: middle estimate off by 6.3-fold (0.80 log units), on the high side; measured number below the stated range.
By their numbers in this assay, from the lowest: compounds 4 and 1 (each within the scatter of the next); then compounds 2 and 3 (each within the scatter of the next).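

In this assay, the thiophen-3-yl group on the carbonyl carbon stands far from 1,3-thiazol-5-yl (a 52-fold lower number from compound 3 to compound 4 (1.72 log units; beyond the scatter)) and from furan-3-yl (a 35-fold lower number from compound 2 to compound 4 (1.54 log units; beyond the scatter)), so a change of one ring atom here can shift growth inhibition strongly. The two thiophene groups cannot be told apart (a 1.6-fold lower number from compound 1 to compound 4 (0.20 log units; within the scatter)), so the low number is not confined to thiophen-2-yl. Going by these compounds, how a phenyl or pyridin-3-yl ring would behave at this place remains open. Nothing available explains why these rings differ.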